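Replacing 4-ethoxyphenyl with 3-chlorophenyl on compound 3

The source may hold more compounds than are shown below. What is called first, only, known or untested is meant among the compounds shown, and "the series" means these compounds.

Of the compounds shown here, three have been tested in a functional assay on Raji cells (Homo sapiens) for cytotoxicity, with a stated time of 72 h (a higher number here means that more compound is needed for the effect, a lower number that less compound is needed), so far. Compound 1 (`C=C[C@@](C)(/C=C/c1ccc(O)cc1)CCC(O)C(C)(C)O`) gives > 26000 nM as a limit and not as a number. Compound 2 (`C=C[C@@](C)(/C=C/c1ccc(O)c(/C=C/C(N)=O)c1)CCC=C(C)C`) gives > 26000 nM as a limit too. Compound 3 (`CCOc1ccc(/C=C/[C@@](C)(/C=C/c2ccc(O)cc2)CCC=C(C)C)cc1`) stands in the same place, with > 26000 nM as a limit and no number of its own. Going by the values given here, the whole of the evidence in this assay is the limit of > 26000 nM in this assay, at which 3 of the 3 values shown sit, and nothing more, so the series offers no measured step to scale a change against.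

Compound 4 (`CC(C)=CCC[C@](C)(/C=C/c1ccc(O)cc1)/C=C/c1cccc(Cl)c1`) has not yet been measured. Relative to compound 3, it carries 3-chlorophenyl in place of 4-ethoxyphenyl on a double-bonded chain carbon bound to a double-bonded chain carbon, a change counted as 3-chlorophenyl in place of 4-ethoxyphenyl on a double-bonded chain carbon bound to a double-bonded chain carbon in full. The rest of the structure stays as it is. The only anchor for the expectation is compound 3 at > 26000 nM in this series, and that value is a limit. The estimated step of an at least 1.1-fold lower number from compound 3 to compound 4 (0.07 log units; that floor lies within the scatter) is expected to stay within the usual scatter, with no direction favoured. The assay may well report only a limit again. Compound 4 is estimated at 22000 nM with an expected range from 8000 nM to 30000 nM in this assay.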

Compound 4, half-maximal effective concentration: > 26000 nM
Compound 4: no number, only a limit (the forecaster's own chance of this, stated with the estimate: 70%); at least 1.1-fold (0.07 log units) between middle value and limit.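

In this assay compound 4 gives > 26000 nM, a limit and not a number. Compound 3 also gives > 26000 nM, again a limit, so no step can be read between compound 3 and compound 4. The compounds shown leave open how far any of them lies from a measurable effect, as all that has been observed is this: the limit of > 26000 nM in this assay, at which 4 of the 4 values shown sit.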